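This account rests on a few compounds, and the source may have more. Where it says the series, first, only, none or still open, it means among the compounds named here.

Of the compounds shown here, three have been measured in a physicochemical assay for lipophilicity, read by HPLC, at pH 7.4; on this read-out lower numbers stand for lower lipophilicity and higher numbers for higher lipophilicity. Going by the values given here, compound 1 `CNCc1cc(-c2cccnc2F)n(S(=O)(=O)c2ccsc2)c1` gives -0.83, and compound 2 `CNCc1cc(-c2cccnc2F)n(S(=O)(=O)c2cccs2)c1` gives -0.69; the only single-point step measured so far, a number 0.14 log units higher from compound 1 to compound 2 (within the scatter), swaps one attachment point of a thiophene for another and stays within the scatter. Compound 3 `CNCc1cn(S(=O)(=O)c2cccc(C)n2)c(-c2cccnc2F)c1F` gives 0.71, the highest of the three numbers, and its distance from both compound 2 and compound 1 is beyond the scatter.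

Compound 4 `CNCc1cn(S(=O)(=O)c2ccc(C)nc2)c(-c2cccnc2F)c1F` is the next step from compound 3. The change is 6-methylpyridin-3-yl in place of 6-methylpyridin-2-yl on a sulfonyl sulfur. Among the compounds with values here, no measured step shows exactly this exchange. The closest hint is the step from compound 1 to compound 2 in this assay, where shifting the attachment point of a five-membered aromatic ring on the same sulfonyl sulfur stayed within the scatter. On that basis compound 4 is expected to land close to compound 3, with a step of about a number 0.11 log units lower from compound 3 to compound 4 (within the scatter) that need not exceed the scatter. The estimate for compound 4 in this assay is 0.6, within a range from 0.1 to 1.1.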

Compound 4, distribution coefficient: 0.62
For compound 4 the middle estimate is 0.02 log units below the measured one; low and high end bracket the measured number.
By their numbers in this assay, from the lowest: compounds 1 and 2 (each within the scatter of the next); then compounds 4 and 3 (each within the scatter of the next).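

In this assay, 6-methylpyridin-3-yl in place of 6-methylpyridin-2-yl on a sulfonyl sulfur gives a step of a number 0.09 log units lower from compound 3 to compound 4 (within the scatter). Going by these compounds alone, this is the first measured exchange at this place involving a six-membered aromatic ring, and the two groups have the same atoms joined differently, so this read-out does not separate these two arrangements. The thiophene pair had shown the same kind of result, a number 0.14 log units higher from compound 1 to compound 2 (within the scatter), and neither of the two measured attachment-point exchanges goes against this, though two pairs on two different cores are a narrow basis.

Nothing available explains why the numbers of compound 3 and compound 4 lie so close. Still open, going by these compounds, is how the read-out would respond to a carboxylic acid, an amine or a longer chain in place of the methyl of 6-methylpyridin-3-yl.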